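The source may hold more compounds than are shown below. What is called first, only, known or untested is meant among the compounds shown, and "the series" means these compounds.

Measured so far in an assay on isolated protein (urine) for inhibition of Myeloperoxidase (Homo sapiens), with a stated time of 5 min; on this read-out lower numbers stand for stronger inhibition and higher numbers for weaker inhibition:

Compound 1 `NCCCc1c[nH]c2c(F)cccc12`: 24 nM
Compound 2 `CNC(=O)CCCc1c[nH]c2ccc(F)cc12`: 40 nM
Compound 3 `NCCSCCCc1c[nH]c2c(F)cccc12`: > 100 nM

Two of these are numbers and one is not. Among the measured compounds shown here, for compound 3 the entry of > 100 nM is a limit of this assay, not a number, and it is the one value that sits at the limit of > 100 nM in this assay, at which 1 of the 3 values shown sits. Among the two numbers, compound 2 with 40 nM and compound 1 with 24 nM lie within the scatter of each other, so no order between them can be read from the data.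

For the measured compounds named here, the only step between measured compounds that differ in one place is an at least 4.1-fold higher number from compound 1 to compound 3 (0.61 log units; beyond the scatter). It concerns a change on the chain amine and not the amide end of the chain, so it gives no direct guide for the step at hand.

Compound 4 `CCNC(=O)CCCc1c[nH]c2ccc(F)cc12` differs from compound 2 by methyl in place of hydrogen on a saturated chain carbon bound to an amide-type nitrogen. With nothing measured on this kind of change, compound 4 is expected to stay close to compound 2, an estimated step of a 1.1-fold higher number from compound 2 to compound 4 (0.05 log units; within the scatter). In this assay compound 4 is therefore estimated at 45 nM, with a range from 20 nM to 100 nM.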

Compound 4, half-maximal inhibitory concentration: 182 nM
Compound 4: the middle estimate sits 4.0-fold (0.61 log units) below what was measured; measured number above the stated range.
By their numbers in this assay, from the lowest: compounds 1 and 2 (each within the scatter of the next); then compound 4.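

In this assay, the amide end of the chain responds to a very small change: methyl in place of hydrogen on a saturated chain carbon bound to an amide-type nitrogen, which turns methylcarbamoyl into ethylcarbamoyl, gives a 4.6-fold higher number from compound 2 to compound 4 (0.66 log units; beyond the scatter). Among the compounds shown here, the earlier compounds showed a step beyond the scatter only on the chain amine, so this is the first such step at the amide end, and it comes from a single added carbon. Nothing given here bears on why this step occurs.

From the compounds shown here alone, it remains open whether a propylcarbamoyl group would continue this trend or a plain carbamoyl group would give a lower number than compound 2. A carboxylic acid in place of the methylcarbamoyl group, and the same ethyl change on the core of compound 1, are open as well.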